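This account rests on a few compounds, and the source may have more. Where it says the series, first, only, none or still open, it means among the compounds named here.

Of the compounds shown here, three built on one shared core have been measured in a functional assay on MCF7 cells (Homo sapiens) for cytotoxicity, read by sulforhodamine B assay, with a stated time of 3 days; on this read-out higher numbers stand for weaker inhibition and lower numbers for stronger inhibition. Compound 1 `O=c1cc[nH]c(=O)n1C1CN(S(=O)(=O)c2ccccc2[N+](=O)[O-])c2ccccc2CO1` gives 50900 nM. Compound 2 `O=[N+]([O-])c1ccccc1S(=O)(=O)N1CC(n2cnc3c(Cl)nc(Cl)nc32)OCc2ccccc21` gives 383 nM, and compound 3 `O=[N+]([O-])c1ccccc1S(=O)(=O)N1CC(n2cnc3nc(Cl)nc(Cl)c32)OCc2ccccc21` gives 990 nM. Among these three numbers compound 2 stands lowest: the step of a 2.6-fold higher number from compound 2 to compound 3 (0.41 log units; beyond the scatter) is modest, while the step of a 130-fold lower number from compound 1 to compound 2 (2.12 log units; beyond the scatter) is large, as is a 51-fold lower number from compound 1 to compound 3 (1.71 log units; beyond the scatter). All three of those steps swap the group on the saturated ring carbon; none of them touches the ring that carries the nitro group.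

Compound 4 `O=S(=O)(c1ccccc1NO)N1CC(n2cnc3c(Cl)nc(Cl)nc32)OCc2ccccc21` is not yet measured. It differs from compound 2 by hydroxyamino in place of nitro on an aromatic carbon. Going by the values given here, the step from compound 2 to compound 4 has no measured counterpart here: every measured step changed a different part of the molecule, so nothing measured shows how this assay answers to a change at this position. Among the compounds with values here, with no measured step pointing in either direction, a step within the scatter, or at most a modest one, is expected in this assay. Compound 4 is expected to give about 800 nM, with a range from 150 nM to 4000 nM, which means an expected step of a 2.1-fold higher number from compound 2 to compound 4 (0.32 log units; beyond the scatter).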

Compound 4, half-maximal inhibitory concentration: 1530 nM
The estimate for compound 4 lay 1.9-fold (0.28 log units) below the measured number; the measured number falls inside the stated range.
By their numbers in this assay, from the lowest: compound 2; then compounds 3 and 4 (each within the scatter of the next); then compound 1.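

Until now every measured step changed the group on the saturated ring carbon, so nothing showed whether the ring carrying the nitro group matters in this assay. Replacing nitro with hydroxyamino gives a 4.0-fold higher number from compound 2 to compound 4 (0.60 log units; beyond the scatter) and so shows that this aromatic carbon does respond to a change of group, with the higher number marking weaker inhibition. The response is modest and much smaller than the large change on the saturated ring carbon (a 130-fold lower number from compound 1 to compound 2 (2.12 log units; beyond the scatter)), and no measured property of either group is available to explain it.

The compounds shown cannot tell whether the weaker inhibition of compound 4 comes from losing nitro or from gaining hydroxyamino, and a plain amine, a carboxylic acid or a hydrogen at the same place would help separate the two. Going by these compounds alone, it also remains open whether the same swap would have a similar effect on compound 3, since this single pair shows the change with only one group on the saturated ring carbon.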